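The source may report more compounds than this note shows. Statements on the series, on what has been measured and on what is new or still open speak of the compounds shown alone.

Measured so far:
- compound 1 `COC(=O)c1ccc(/C=C/C(=O)c2cc(OC)ccc2OC)cc1`: 3510 nM
- compound 2 `CCNC(=O)c1ccc(/C=C/C(=O)c2cc(OC)ccc2OC)cc1`: 3760 nM

In a functional assay on NTUB1 cells (Homo sapiens) for cytotoxicity, read by MTT assay, with a stated time of 72 h (on this read-out lower numbers stand for stronger inhibition and higher numbers for weaker inhibition), compound 2 gives 3760 nM, level with compound 1 within the scatter. The next analogue, compound 3 `COc1ccc(OC)c(C(=O)/C=C/c2ccc(C(=O)NC3CCCCC3)cc2)c1`, has cyclohexyl in place of ethyl on an amide-type nitrogen. Within the data shown here, the only measured step with any bearing on this is a 1.1-fold higher number from compound 1 to compound 2 (0.03 log units; within the scatter), which put ethylamino in place of methoxy on a carbonyl carbon. Among the measured compounds shown here, no measured pair varies the group on the amide-type nitrogen, so this evidence is indirect and gives no direction. In this assay no change beyond the scatter is therefore expected, and the range is kept wide. The expected step is a 1.0-fold lower number from compound 2 to compound 3 (0.02 log units; within the scatter). The estimated value for compound 3 is 3600 nM, with an expected range of 1200 nM to 10000 nM.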

Compound 3, half-maximal inhibitory concentration: 2250 nM
The estimate for compound 3 lay 1.6-fold (0.20 log units) above the measured number; low and high end bracket the measured number.
By their numbers in this assay, from the lowest: compounds 3, 1 and 2 (each within the scatter of the next).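

In this assay, among these compounds, the group on the amide-type nitrogen now varies for the first time: cyclohexyl in place of ethyl gives a 1.7-fold lower number from compound 2 to compound 3 (0.22 log units; within the scatter). This position thus carries a six-membered non-aromatic ring of carbon only, with 6 heavy atoms in place of 2, without a change beyond the scatter, and going from the methyl ester straight to the cyclohexyl amide gives a 1.6-fold lower number from compound 1 to compound 3 (0.19 log units; within the scatter), so the methyl ester and both amides remain level. No supporting data bear on why these numbers stay together.

Whether any group at this position can move the number beyond the scatter remains open, as the compounds shown carry only ethyl and cyclohexyl on this nitrogen. On these data alone, how a phenyl ring or a chain ending in an amine on this nitrogen would read is also open, as is a carboxylic acid in place of the amide.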